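Trifluoromethyl hydroxyamides: inverting the benzylic alcohol stereocentre

The compounds below may be only part of what the source reports. "The series", "measured", "known", "first", "only" and "open" are said of these compounds alone.

Values in an assay on a protein complex (Cavia porcellus) with sulfonylurea receptors; K-ATP channels (Homo sapiens) as the target; a higher number here means a weaker inhibitor, a lower number a stronger inhibitor:
Compound 1, `CCN(CC)S(=O)(=O)c1ccc(NC(=O)C(C)(O)C(F)(F)F)cc1`: 810 nM.
Compound 2, `CC(O)(C(=O)Nc1ccc(-c2nn[nH]n2)cc1)C(F)(F)F`: > 30000 nM, a limit of the assay.
Compound 3, `CC(O)(C(=O)Nc1ccc([C@@H](O)c2ccccc2)cc1)C(F)(F)F`: > 30000 nM, a limit of the assay.

Compound 3 stands at the limit of this assay; two of the three values shown sit there (the limit of > 30000 nM in this assay, at which 2 of the 3 values shown sit). Compound 4, `CC(O)(C(=O)Nc1ccc([C@H](O)c2ccccc2)cc1)C(F)(F)F`, differs from compound 3 only in stereochemistry: the two compounds have the same atoms and bonds; at least one stereo element is drawn with a configuration in one of them and without one in the other: 1 of 2 stereo elements differ; a stereocentre at a saturated chain carbon is drawn S in compound 3 and R in compound 4. Within the data shown here, no measured step covers an inversion of this kind. Among the measured compounds shown here, the steps that bear on this part of the series are an at least 37-fold higher number from compound 1 to compound 3 (1.56 log units; beyond the scatter) and an at least 37-fold higher number from compound 1 to compound 2 (1.56 log units; beyond the scatter), both leaving hydroxy(phenyl)methyl and 2H-tetrazol-5-yl far from diethylsulfamoyl, while a step that the two limits leave unreadable from compound 2 to compound 3 cannot be read. In this assay the expected step is a step that the limit leaves unreadable from compound 3 to compound 4, nothing beyond the scatter, and compound 4 will most probably remain at the limit. Compound 4 is estimated at 40000 nM, between 10000 nM and 150000 nM.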

Compound 4, half-maximal inhibitory concentration: > 30000 nM
Compound 4 was reported as a limit; the forecaster's own chance of this, stated with the estimate: 85%; the middle value is on the limit's open side.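

In this assay compound 4 gives > 30000 nM, a limit of the assay. Inverting the stereocentre of hydroxy(phenyl)methyl therefore leaves this group at the limit in both drawn configurations, and it stays far from diethylsulfamoyl, with an at least 37-fold higher number from compound 1 to compound 4 (1.56 log units; beyond the scatter). The steps among compound 2, compound 3 and compound 4 cannot be read: the limit of > 30000 nM in this assay, at which 3 of the 4 values shown sit.

As far as these compounds go, whether the two configurations differ at all remains open. Also open, from the compounds shown here alone, is whether a carboxylic acid or a dimethylamino group in place of diethylsulfamoyl would come near compound 1 at 810 nM.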